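The source may report more compounds than this note shows. Statements on the series, on what has been measured and on what is new or still open speak of the compounds shown alone.

Measured so far:
- compound 1, `CC(=O)OC(C)(C)C1CC/C(C)=C/CC/C(C)=C/CCC2=C[C@@H]1OC2=O`: 1.2 ug/mL in a functional assay on P388 cells (Mus musculus) for cytotoxicity, read by MTT assay, with a stated time of 3 days; a higher number here means that more compound is needed for the effect, a lower number that less compound is needed
- compound 2, `C=C(C)C1CC[C@@]2(C)CCC[C@@](C)(OC(C)=O)[C@@H]2C1`: 2.44 ug/mL

Of the compounds shown here, two have been tested in this assay. Compound 1 gives 1.2 ug/mL, and compound 2 gives 2.44 ug/mL. Compound 2 therefore stands with the highest number of the two, meaning more of it is needed than of compound 1, and the gap between them lies beyond the usual scatter of this kind of measurement.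

The next compound, compound 3, `C=C(C)C1CC[C@@]2(C)CCC[C@@](C)(O)[C@@H]2C1`, differs from compound 2 in one place only: hydrogen in place of acetyl on an oxygen on a saturated carbon. Put another way, an acetoxy group becomes a hydroxy group.

Among the measured compounds shown here, no measured pair here shows what such a change does in this assay, so there is no precedent to lean on. The expectation is a modest shift toward a higher number, though a result within the scatter would not be surprising; the step from compound 2 to compound 3 is expected to be a 1.4-fold higher number from compound 2 to compound 3 (0.16 log units; within the scatter). Compound 3 is therefore estimated at 3.5 ug/mL, with a plausible range from 1.2 ug/mL to 10 ug/mL.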

Compound 3, concentration for half-maximal effect: 3.86 ug/mL
Compound 3: the middle estimate sits 1.1-fold (0.04 log units) below what was measured; the measured number falls inside the stated range.
By their numbers in this assay, from the lowest: compound 1; then compounds 2 and 3 (each within the scatter of the next).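

In this assay, the change from acetoxy to hydroxy on this oxygen gives a 1.6-fold higher number from compound 2 to compound 3 (0.20 log units; within the scatter). Among the compounds shown here, this is the first measured pair for this change, and it shows that, on this core, the two compounds cannot be told apart in this assay, so the cytotoxic effect does not depend on the acetyl being present. Nothing available here bears on what lies behind this result.

On these data alone, it remains open whether a methyl ether, a longer ester such as a butyrate, or an amine in the place of the hydroxy group would also leave the number within the scatter. As far as these compounds go, it is also open whether the same swap of acetyl for hydrogen on the acetoxy group of compound 1 would give a similarly small step.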